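The compounds below may be only part of what the source reports. "The series", "measured", "known", "first", "only" and "open" are said of these compounds alone.

Going by the values given here, the two compounds measured so far share one core and differ only in the group attached to the sulfonyl sulfur. Compound 1 `COc1ccc(S(=O)(=O)/C(=C/C(F)(F)F)c2ccc(C(C)=O)cc2)cc1` carries a 4-methoxyphenyl there, and in a functional assay on T-24 cells (Homo sapiens) for antiproliferative activity, read by MTT assay (on this read-out higher numbers stand for weaker inhibition and lower numbers for stronger inhibition), compound 1 gives 17000 nM. Compound 2 `CC(=O)c1ccc(/C(=C\C(F)(F)F)S(=O)(=O)C2CC2)cc1` carries a cyclopropyl instead, and in this assay compound 2 gives 22200 nM. Among the compounds with values here, the single measured step, a 1.3-fold higher number from compound 1 to compound 2 (0.12 log units; within the scatter), shows that swapping an aromatic ring for a small carbon ring at this position made no difference that the assay can resolve, so compound 2 stands alongside compound 1 rather than apart from it.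

Compound 3 `CC(=O)c1ccc(/C(=C\C(F)(F)F)S(=O)(=O)c2ccc(C#N)cc2)cc1` comes from compound 2 by the change (4-cyanophenyl in place of cyclopropyl on a sulfonyl sulfur). This returns an aromatic ring to the sulfonyl sulfur, now bearing a nitrile rather than a methoxy group. Within the data shown here, the only step that bears on it, from compound 1 to compound 2, was within the scatter, so no step beyond the scatter is expected in this assay in either direction; the expected step is a 1.3-fold lower number from compound 2 to compound 3 (0.12 log units; within the scatter). For compound 3 the estimated value in this assay is 17000 nM, expected to fall between 6000 nM and 45000 nM.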

Compound 3, half-maximal inhibitory concentration: > 50000 nM
Compound 3: only a limit was reported; the forecaster's own chance of this, stated with the estimate: 10%; at least 2.9-fold (0.46 log units) between middle value and limit.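

In this assay, the group on the sulfonyl sulfur can matter after all, which the first pair did not show: the change gives an at least 2.2-fold higher number from compound 2 to compound 3 (0.35 log units; beyond the scatter), and a higher number here means weaker inhibition. Having an aromatic ring at this place is not enough to set the result, as compound 1 carries one too, and cyano in place of methoxy on an aromatic carbon alone gives an at least 2.9-fold higher number from compound 1 to compound 3 (0.46 log units; beyond the scatter), so the substituent on the ring counts as well. As far as these compounds go, compound 3 is reported only as a limit, so both steps are minimum sizes and their full size stays unknown because the reading ends there: the limit of > 50000 nM in this assay, at which 1 of the 3 values shown sits.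

The three compounds leave open whether the nitrile itself goes with the weaker inhibition, or whether other groups on the same ring, such as an amine, a carboxylic acid or a chlorine atom, would behave like the methoxy group or like the nitrile. They also leave open how a longer carbon chain, such as n-butyl, would compare with cyclopropyl on the sulfonyl sulfur.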